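The source may hold more compounds than are shown below. What is called first, only, known or untested is meant among the compounds shown, and "the series" means these compounds.

Measured compounds:
compound 1, `Cc1ccccc1-n1nncc1CN1C(=O)C2(C(C#N)=C(N)Oc3c(N)cc4nc5ccccc5nc4c32)c2ccccc21`. In a functional assay on MCF7 cells (Homo sapiens) for antiproliferative activity, read by MTT assay, with a stated time of 48 h (on this read-out lower numbers stand for stronger inhibition and higher numbers for weaker inhibition), compound 1 gives > 50000 nM, a limit of the assay rather than a number.
compound 2, `Cc1ccc(Cl)cc1-n1nncc1CN1C(=O)C2(C(C#N)=C(N)Oc3c(N)cc4nc5ccccc5nc4c32)c2ccccc21`. In this assay compound 2 gives 43500 nM.

Going by the values given here, compound 2 is thus the only compound with an actual number in this assay; the other result is a limit, so no ranking between the two can be drawn. The two differ only in that compound 2 carries a chloro in place of hydrogen on an aromatic carbon, and that step, an at least 1.1-fold lower number from compound 1 to compound 2 (0.06 log units; that floor lies within the scatter), sits within the scatter of repeated measurements.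

Compound 3, `N#CC1=C(N)Oc2c(N)cc3nc4ccccc4nc3c2C12C(=O)N(Cc1cnnn1-c1c(Cl)cc(Cl)cc1Cl)c1ccccc12`, is not yet measured. It differs from compound 2 in one place: 2,4,6-trichlorophenyl in place of 5-chloro-2-methylphenyl on an aromatic nitrogen. Among the compounds with values here, the only measured step that touches this aryl group is the one from compound 1 to compound 2, which was small, so there is no sign that chlorine on this ring moves the number far. The step from compound 2 to compound 3 is therefore expected to stay within the scatter, a 1.1-fold lower number from compound 2 to compound 3 (0.04 log units; within the scatter), with a real chance that only a limit is reported. For compound 3 the estimate in this assay is 40000 nM, in a range from 15000 nM to 100000 nM.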

Compound 3, half-maximal inhibitory concentration: 37800 nM
The estimate for compound 3 lay 1.1-fold (0.02 log units) above the measured number, and the stated range covers the measured number.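

Even a larger exchange at this position leaves the number in the same place: compound 2 and compound 3 cannot be told apart, with a 1.2-fold lower number from compound 2 to compound 3 (0.06 log units; within the scatter). The earlier step added a single chloro, whereas this one replaces 5-chloro-2-methylphenyl with 2,4,6-trichlorophenyl, so the ring loses its methyl and carries more chlorine, yet this assay still shows no difference beyond the scatter. The comparison with the limit adds little, as it gives only an at least 1.3-fold lower number from compound 1 to compound 3 (0.12 log units; that floor lies within the scatter), and compound 1 remains a limit of the assay rather than a number: the limit of > 50000 nM in this assay, at which 1 of the 3 values shown sits.

For these three compounds, then, the methyl and chlorine pattern on this phenyl ring has not been seen to separate one compound from another, though a single position and three compounds cannot show that this holds more widely. Open, from the compounds shown here alone, is how an amine or a carboxylic acid on this ring, or a longer alkyl chain in its place, would read, and whether a change to the shared core would move the number further than any change seen at this position.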